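Acylhydrazone aryl variation on a shared thiazole-urea core

This account rests on a few compounds, and the source may have more. Where it says the series, first, only, none or still open, it means among the compounds named here.

Measured so far in a functional assay on HeLa cells (Homo sapiens) for inhibition, read by MTT assay, with a stated time of 72 h; on this read-out lower numbers stand for stronger inhibition and higher numbers for weaker inhibition:
compound 1 `CN(C(=O)NC(=O)c1ccc(F)c(F)c1)c1nc(C(F)(F)F)c(C(=O)N/N=C/c2ccc(C(F)(F)F)cc2)s1` gives 5.1 ug/mL
compound 2 `CN(C(=O)NC(=O)c1ccc(F)c(F)c1)c1nc(C(F)(F)F)c(C(=O)N/N=C/c2ccccc2C(F)(F)F)s1` gives 9.24 ug/mL
compound 3 `CN(C(=O)NC(=O)c1ccc(F)c(F)c1)c1nc(C(F)(F)F)c(C(=O)N/N=C/c2cc(C(F)(F)F)cc(C(F)(F)F)c2)s1` gives 4.45 ug/mL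

Compound 3 has the lowest of the three numbers in this assay, but its nearest neighbour, compound 1, sits within the scatter of it, so no order between compound 3 and compound 1 can be claimed; only compound 2 lies beyond the scatter of compound 3.

Compound 4 `CN(C(=O)NC(=O)c1ccc(F)c(F)c1)c1nc(C(F)(F)F)c(C(=O)N/N=C/c2cccc(C(F)(F)F)c2)s1` is the not yet measured member. It differs from compound 3 in one place: hydrogen in place of trifluoromethyl on an aromatic carbon. For the measured compounds named here, the only measured step that bears on the aryl group is a 1.8-fold higher number from compound 1 to compound 2 (0.26 log units; within the scatter), a move of the trifluoromethyl around the ring that stayed within the scatter. Compound 3 and compound 1 likewise differ by one trifluoromethyl on that ring, and their two values show almost no separation. Both comparisons suggest that the count and placing of trifluoromethyl groups on this ring does little in this assay, so for a 1.2-fold higher number from compound 3 to compound 4 (0.09 log units; within the scatter) a step within the scatter is expected, if anything toward a slightly higher number.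

Compound 4 is therefore estimated at 5.5 ug/mL, with a range of 2.8 ug/mL to 11 ug/mL.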

Compound 4, half-maximal inhibitory concentration: 4.21 ug/mL
Compound 4: the middle estimate sits 1.3-fold (0.12 log units) above what was measured; the measured number falls inside the stated range.
By their numbers in this assay, from the lowest: compounds 4, 3, 1 and 2 (each within the scatter of the next, the first and the last beyond it).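

In this assay, hydrogen in place of trifluoromethyl on the aromatic ring of compound 3 gives no separable result (a 1.1-fold lower number from compound 3 to compound 4 (0.02 log units; within the scatter)), so among the compounds shown, the second trifluoromethyl group of compound 3 brings no measurable difference from the single group of compound 4. For the compounds shown here, the single-group placements can now be read more fully: 3-(trifluoromethyl)phenyl cannot be separated from 4-(trifluoromethyl)phenyl (a 1.2-fold lower number from compound 1 to compound 4 (0.08 log units; within the scatter)), whereas its step from 2-(trifluoromethyl)phenyl is modest but is the first single-group placement step on this ring to pass the scatter (a 2.2-fold lower number from compound 2 to compound 4 (0.34 log units; beyond the scatter)). No supporting measurement on these compounds offers an explanation for this pattern.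

Every aryl group shown carries only trifluoromethyl, so it remains open whether an amine, a carboxylic acid or a methoxy group on the same aromatic carbon would give a number beyond the scatter of compound 4. Also open, from the compounds shown here alone, is how a plain phenyl group, with hydrogen in place of the remaining trifluoromethyl, would compare with compound 4 on the shared core.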